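The source may report more compounds than this note shows. Statements on the series, on what has been measured and on what is new or still open speak of the compounds shown alone.

Measured compounds in a functional assay on MCF7 cells (Homo sapiens) for cytotoxicity, read by sulforhodamine B assay, with a stated time of 48 h; on this read-out lower numbers stand for stronger inhibition and higher numbers for weaker inhibition:

compound 1, `CC(=O)OC[C@H]1O[C@@H](n2cc(Cn3cc(/C=C4/C(=O)Nc5ccccc54)c4ccccc43)nn2)[C@H](OC(C)=O)[C@@H](OC(C)=O)[C@@H]1OC(C)=O`, 22200 nM
compound 2, `CC(=O)OC[C@H]1O[C@@H](n2cc(CN3C(=O)/C(=C\C=C\c4ccccc4)c4ccccc43)nn2)[C@H](OC(C)=O)[C@@H](OC(C)=O)[C@@H]1OC(C)=O`, 34100 nM
compound 3, `CC(=O)OC[C@H]1O[C@@H](n2cc(CN3C(=O)/C(=C/C=C/c4ccccc4)c4ccccc43)nn2)[C@H](OC(C)=O)[C@@H](OC(C)=O)[C@@H]1OC(C)=O`, 53200 nM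

Compound 2 sits between the other two numbers: compound 1 gives a lower number and compound 3 a higher one, but both gaps are within the scatter, so the three compounds cannot be told apart on this read-out. Within the data shown here, the only single-point step among them is a 1.6-fold higher number from compound 2 to compound 3 (0.19 log units; within the scatter), which rests on the fact that compounds 2 and 3 differ only in the configuration as drawn and shows that redrawing the double bond leaves the number where it was.

Compound 4, `CCC/C=C1\C(=O)N(Cc2cn([C@@H]3O[C@H](COC(C)=O)[C@@H](OC(C)=O)[C@H](OC(C)=O)[C@H]3OC(C)=O)nn2)c2ccccc21`, is not yet measured. Relative to compound 2 the change is propyl in place of 2-phenylethenyl on a double-bonded chain carbon bound to a double-bonded ring carbon. Among the measured compounds shown here, no measured step involves this kind of exchange; the only step in hand is the configurational one between compound 2 and compound 3, and it stayed within the scatter. There is thus nothing in the series that points to a shift in either direction for compound 4, and no step beyond the scatter is assumed, though the uncertainty is wide for want of a comparable step.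

Compound 4 is therefore estimated at 40000 nM, with a range from 14000 nM to 120000 nM. This expectation corresponds to a step of a 1.2-fold higher number from compound 2 to compound 4 (0.07 log units; within the scatter).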

Compound 4, half-maximal inhibitory concentration: 25000 nM
Estimate against measurement, compound 4: 1.6-fold (0.20 log units) above, and the stated range covers the measured number.
By their numbers in this assay, from the lowest: compounds 1, 4, 2 and 3 (each within the scatter of the next, the first and the last beyond it).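

In this assay there is a 1.4-fold lower number from compound 2 to compound 4 (0.13 log units; within the scatter), so the exchange of 2-phenylethenyl for propyl on a double-bonded chain carbon bound to a double-bonded ring carbon stays within the scatter. The earlier compounds shown here varied only the configuration drawn at this part of the shared core, whereas this step replaces the group itself: the six-membered aromatic ring and the chain double bond leave, and 8 heavy atoms give way to 3, without a step beyond the scatter in this one pair. Nothing in hand gives a cause for this step.

The groups shown at this place are hydrocarbons only, so it remains open whether an amine, a carboxylic acid or a longer chain such as octyl would give a step beyond the scatter. Also open, on these data alone, are compound 4 with its double bond drawn the other way and the effect of free hydroxyl groups in place of the acetate esters on the shared core.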